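The source may report more compounds than this note shows. Statements on the series, on what has been measured and on what is new or still open speak of the compounds shown alone.

Of the compounds shown here, two of a shared core have been measured in a functional assay on the whole organism (strain Swiss albino) for inhibition, with Mus musculus as the target, in the writhing test, with stated times of 30 min and 15 min, at a dose of 50 mg/kg by the oral route; on this read-out higher numbers stand for more inhibition at the one dose given (going by the name of the read-out) and lower numbers for less inhibition. Compound 1 `Cc1cccc(/N=C2/NC(=O)/C(=C/c3ccccn3)S2)c1` gives 52.3% in this assay. Compound 2 `Cc1cccc(C)c1/N=C1/NC(=O)/C(=C/c2ccccn2)S1` gives 51.5% in this assay, the lower of the two numbers, with compound 1 the nearest neighbour at a value a little higher; that gap lies within the scatter, so the two compounds cannot be told apart on this read-out. Compound 3 `Cc1ccccc1/N=C1/NC(=O)/C(=C/c2ccccn2)S1` has not yet been measured in this assay. It differs from compound 2 in one place: hydrogen in place of methyl on an aromatic carbon. A methyl of one heavy atom leaves and a hydrogen enters, so compound 3 carries a single methyl on that ring, as compound 1 does. Since the two measured compounds agree within the scatter, no step beyond the scatter is expected from compound 2 to compound 3, and a change of a number 1.5 percentage points lower from compound 2 to compound 3 (within the scatter) is estimated. Compound 3 is expected to give about 50% in this assay, within a range of 38% to 62%.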

Compound 3, a percentage reported as inhibition, in the whole organism at one dose (the size of the read-out at that dose, not a potency): 43.6%
The estimate for compound 3 lay 6.4 percentage points above the measured number; the measured number falls inside the stated range.
By their numbers in this assay, from the lowest: compounds 3, 2 and 1 (each within the scatter of the next).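

In this assay, hydrogen in place of methyl on an aromatic carbon, ortho to a large group, gives a number 7.9 percentage points lower from compound 2 to compound 3 (within the scatter), so this methyl is not shown to matter on this read-out. 2-Methylphenyl in place of 3-methylphenyl on a double-bonded nitrogen gives a number 8.7 percentage points lower from compound 1 to compound 3 (within the scatter), so the two placings of the single methyl cannot be told apart in this assay either. Nothing at hand bears on why these steps take the sizes they do.

All the compounds shown carry only methyl groups on this ring, so it remains open whether a chlorine atom, a methoxy group or an amine at this place would give a step beyond the scatter. Going by these compounds, how a longer chain in place of the methyl would read in this assay also remains open.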